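Compound 4: One Chlorine Instead of Two on the Phenyl Group

The source may hold more compounds than are shown below. What is called first, only, known or untested is meant among the compounds shown, and "the series" means these compounds.

Compound 1 `CN(C)CCn1cnnc1-c1cc(Oc2ccc(NC(=O)N/N=C/c3c(Cl)cccc3Cl)cc2F)ccn1` — 3320 nM
Compound 2 `COc1cc(/C=N/NC(=O)Nc2ccc(Oc3ccnc(-c4nncn4CCN(C)C)c3)c(F)c2)cc(OC)c1OC` — "not determined" (no result reported)
Compound 3 `CN(C)CCn1cnnc1-c1cc(Oc2ccc(NC(=O)N/N=C/c3cccc(Cl)c3Cl)cc2F)ccn1` — 6130 nM

Three compounds share a core, and two of them carry a number in an ADME assay on WI-38 cells (Homo sapiens) for cytotoxicity, read by MTT assay, with a stated time of 72 h; on this read-out higher numbers stand for weaker inhibition and lower numbers for stronger inhibition. Compound 2 has no result in this assay. Compound 3 gives 6130 nM in this assay, and compound 1 gives 3320 nM. Going by the values given here, the only step among measured compounds, a 1.8-fold higher number from compound 1 to compound 3 (0.27 log units; within the scatter), lies within the scatter, so the two numbers cannot be told apart and compound 3 stands alongside compound 1 rather than apart from it.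

Compound 4 `CN(C)CCn1cnnc1-c1cc(Oc2ccc(NC(=O)N/N=C/c3ccc(Cl)cc3)cc2F)ccn1` differs from compound 3 in one place: 4-chlorophenyl in place of 2,3-dichlorophenyl on a carbon with a double bond to nitrogen. Among the compounds with values here, no measured pair changes the count of chlorines on this phenyl group, so nothing bears directly on the step. Within the data shown here, the one step that touches the same phenyl group, a 1.8-fold higher number from compound 1 to compound 3 (0.27 log units; within the scatter), moved the chlorines without leaving the scatter. From that, compound 4 is expected to stay close to compound 3, with the step of a 1.2-fold lower number from compound 3 to compound 4 (0.09 log units; within the scatter) expected to remain within the scatter in either direction. Compound 4 is therefore estimated at 5000 nM, with a range from 2000 nM to 13000 nM.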

Compound 4, half-maximal inhibitory concentration: 1870 nM
For compound 4 the middle estimate is 2.7-fold (0.43 log units) above the measured one; measured number outside the range, below it.
By their numbers in this assay, from the lowest: compounds 4, 1 and 3 (each within the scatter of the next, the first and the last beyond it).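

Going by these compounds alone, with 4-chlorophenyl in place of 2,3-dichlorophenyl on the carbon with a double bond to nitrogen, this assay gives a 3.3-fold lower number from compound 3 to compound 4 (0.52 log units; beyond the scatter), the first step at this position to lie beyond the scatter and the first measured change in the number of chlorines on this phenyl group. The same group in place of 2,6-dichlorophenyl gives a 1.8-fold lower number from compound 1 to compound 4 (0.25 log units; within the scatter), so going from two chlorines to one does not separate the compounds in both pairs, and with compound 1 and compound 3 themselves within the scatter of each other, these steps do not establish that the arrangement of the chlorines matters. Nothing in the information given accounts for the step from the dichlorinated compounds to the one with a single chlorine.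

The compounds shown leave open whether 2-chlorophenyl or 3-chlorophenyl would read like 4-chlorophenyl, which would separate the number of chlorines from where they sit. They also leave open whether the chlorine of compound 4 is needed at all, as a plain phenyl group, a 4-fluorophenyl group or a phenyl group carrying an amine or a carboxylic acid would show.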